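This account rests on a few compounds, and the source may have more. Where it says the series, first, only, none or still open, it means among the compounds named here.

Compound 2 `CCN(CC)Cc1ccc(NC(=O)Nc2ccc3ncnc(Nc4cccc(C(F)(F)F)c4)c3c2)cc1` gives 3980 nM in a functional assay on A-431 cells (Homo sapiens) for antiproliferative activity, read by MTT assay, with a stated time of 72 h (on this read-out lower numbers stand for stronger inhibition and higher numbers for weaker inhibition), the highest of the two numbers in the set, with compound 3 `C#Cc1cccc(Nc2ncnc3ccc(NC(=O)Nc4ccc(CN(CC)CC)cc4)cc23)c1` nearest at 1240 nM. Compound 1 `CN1CCN(Cc2ccc(NC(=O)Nc3ccc4ncnc(Nc5cccc(C(=O)N6CCCC6)c5)c4c3)cc2)CC1` in this assay gives > 10000 nM, which is a limit of the assay and not a number. Within the data shown here, the one step measured within the set, a 3.2-fold lower number from compound 2 to compound 3 (0.51 log units; beyond the scatter), concerns the aryl-amine end of the shared core and leaves the urea-bearing side untouched.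

Compound 4 `CCN(CC)c1ccc(NC(=O)Nc2ccc3ncnc(Nc4cccc(C(F)(F)F)c4)c3c2)cc1` differs from compound 2 by diethylamino in place of (diethylamino)methyl on an aromatic carbon. Among the measured compounds shown here, no measured pair exchanges (diethylamino)methyl for diethylamino, so no step bears directly on this change; the only step in hand, a 3.2-fold lower number from compound 2 to compound 3 (0.51 log units; beyond the scatter), alters a different part of the molecule, and compound 1 differs from compound 2 in more than one place, so it offers no single-change comparison. The expectation in this assay is therefore a step of no clear direction and not beyond the scatter, a 1.3-fold higher number from compound 2 to compound 4 (0.10 log units; within the scatter), with a wide range set around it to allow for an untested change. Compound 4 is estimated at 5000 nM, expected to fall between 1500 nM and 16000 nM.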

Compound 4, half-maximal inhibitory concentration: 6460 nM
For compound 4 the middle estimate is 1.3-fold (0.11 log units) below the measured one, within the range that was stated.
By their numbers in this assay, from the lowest: compound 3; then compounds 2 and 4 (each within the scatter of the next). At a limit, above all of these: compound 1.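

Moving the diethylamino nitrogen from a carbon link straight onto the aromatic carbon gives the series its only reading on the urea-bearing side: in this assay, the exchange gives a 1.6-fold higher number from compound 2 to compound 4 (0.21 log units; within the scatter). At this position, para to a large group, the carbon link therefore makes no difference that this read-out can resolve, at least with trifluoromethyl at the other end of the shared core. Nothing shown gives a measured cause for this result, or for the high numbers of both compounds.

Going by these compounds, whether the same exchange would also stay within the scatter with the ethynyl group of compound 3 remains open, since this one pair carries trifluoromethyl only. Also open, on these data alone, is how this position responds to a different kind of group, such as a morpholine ring, a carboxylic acid or a longer chain ending in diethylamino, as this pair explores only how the amine is attached and not its nature.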